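Selenium-bearing core: removing the methyl from selenium

A few compounds are considered here, and "the series" means these few. Any claim that something is new, unique, unknown or untested is made for them only; others in the source may bear on it.

Compound 1 `C[Se]c1nc(N)c2ccccc2n1` in a functional assay on CCRF-CEM cells (Homo sapiens) for cytotoxicity, read by MTT assay, with a stated time of 72 h (a higher number here means that more compound is tolerated, a lower number that less compound is tolerated), gives > 100000 nM, a value that is a limit of the assay rather than a number.
Compound 2 `CSc1nc(NCCCCc2ccccc2)c2ccccc2n1` gives > 100000 nM in this assay, again a limit.
Compound 3 `C[Se]c1nc(NCc2ccccc2)c2ccccc2n1` gives 83500 nM in this assay.

For the measured compounds named here, compound 1 stands at the limit of > 100000 nM in this assay, at which 2 of the 3 values shown sit, so no number is known for it, only a limit; compound 3 is the one value here that is a number, and compound 2 shares the limit with compound 1. Compound 4 `Nc1nc([SeH])nc2ccccc12` has not yet been tested. It differs from compound 1 by a single change: hydrogen in place of methyl on a selenium. Going by the values given here, no pair of tested compounds shows what such a change does in this assay. The expectation for the step from compound 1 to compound 4 is therefore no change beyond the usual scatter, with a number no higher from compound 1 to compound 4 (the limit leaves the size open) as the estimated step. Compound 4 is expected to give about 100000 nM in this assay, most likely again reported as a limit, with a plausible range from 30000 nM to 300000 nM.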

Compound 4, concentration lethal to 50% of the cells: 79100 nM
For compound 4 the middle estimate is 1.3-fold (0.10 log units) above the measured one; the range from low to high includes it.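

For the compounds shown here, this is the first reading of hydrogen in place of methyl on a selenium, and the change gives an at least 1.2-fold lower number from compound 1 to compound 4 (0.10 log units; that floor lies within the scatter) in this assay. With hydrogen on the selenium, compound 4 gives a real number, 79100 nM, so this position now has one measured value to compare against. The step remains only a floor, and its full size cannot be read, because compound 1 has a limit rather than a number: the limit of > 100000 nM in this assay, at which 2 of the 4 values shown sit.

The compounds shown leave open what an ethyl group or a longer chain on the selenium would do in this assay. They also leave open whether the same swap of methyl for hydrogen would give a similar result on the core of compound 3, which has a measured value to start from.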